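The source may report more compounds than this note shows. Statements on the series, on what has been measured and on what is new or still open speak of the compounds shown alone.

Measured compounds and their values in an assay on L1.2 cells for binding affinity to C-C chemokine receptor type 8 (Homo sapiens); a higher number here means a weaker inhibitor, a lower number a stronger inhibitor:
compound 1, `O=C(Nc1ccc(S(=O)(=O)NC2CCCCC2)c2ccccc12)c1ccccc1`, 4.4 nM
compound 2, `CCOC(=O)N1CCC(NS(=O)(=O)c2ccc(NC(=O)c3ccccc3)c3ccccc23)CC1`, 0.17 nM
compound 3, `Cc1ccccc1C(=O)Nc1ccc(S(=O)(=O)NC2CCN(C(=O)C3CCCC3)CC2)c2ccccc12`, 9.1 nM

Compound 3 gives the highest number of the three in this assay; compound 1 is nearest, compound 2 furthest below it. Compound 4, `CCN(CC)CCCC(=O)N1CCC(NS(=O)(=O)c2ccc(NC(=O)c3ccccc3C)c3ccccc23)CC1`, differs from compound 3 in one place: 3-(diethylamino)propyl in place of cyclopentyl on a carbonyl carbon. For the measured compounds named here, no measured step touches this carbonyl carbon. Going by the values given here, the only step on record, a 26-fold lower number from compound 1 to compound 2 (1.41 log units; beyond the scatter), sits on a sulfonamide nitrogen and shows that an altered tail can shift the number greatly; its direction cannot be carried over to the present change. Compound 4 is therefore expected to stay near compound 3, with a step of a 1.8-fold lower number from compound 3 to compound 4 (0.26 log units; within the scatter) and wide uncertainty. The estimate for compound 4 is 5 nM, between 0.8 nM and 25 nM.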

Compound 4, inhibition constant: 567 nM
Estimate against measurement, compound 4: 110-fold (2.05 log units) below; the measured number lies above the stated range.
By their numbers in this assay, from the lowest: compound 2; then compound 1; then compound 3; then compound 4.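

In this assay, for the compounds shown here, the group on this carbonyl carbon proves far from neutral: 3-(diethylamino)propyl in place of cyclopentyl gives a 62-fold higher number from compound 3 to compound 4 (1.79 log units; beyond the scatter) as the first measured step at this place. The exchange replaces a five-membered ring of carbon only with an open chain carrying a nitrogen, and compound 4 has the highest number of the four. Nothing on record accounts for this step.

From the compounds shown here alone, it remains open whether the chain itself or its diethylamino end matters. A plain pentyl chain or a piperidine ring on this carbonyl would help separate the two.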